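Aziridinylquinone series: a third aziridine for the methoxyethyl chain

The source may hold more compounds than are shown below. What is called first, only, known or untested is meant among the compounds shown, and "the series" means these compounds.

Within the three measured members of this series compound 1 `COCCC1=C(N2CC2)C(=O)C(C)=C(N2CC2)C1=O` stands highest: in a functional assay on L1210 cells (Mus musculus), with a stated time of 1 days (a lower number here means a less potent compound, a higher number a more potent compound, by a factor of ten per unit of this negative logarithm), compound 1 gives 5.12. Its nearest neighbour is compound 2 `COCCC1=C(N2CC2)C(=O)C(CCOC)=C(N2CC2)C1=O`, with 4.71, and the furthest is compound 3 `CC1=C(N2CC2)C(=O)C(CCCc2ccccc2)=C(N2CC2)C1=O`, with 3.6. Both measured steps run downward from compound 1: a number 0.41 log units lower from compound 1 to compound 2 (beyond the scatter), and a number 1.52 log units lower from compound 1 to compound 3 (beyond the scatter).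

Compound 4 `CC1=C(N2CC2)C(=O)C(N2CC2)=C(N2CC2)C1=O` is the next candidate. It differs from compound 1 in one place: aziridin-1-yl in place of 2-methoxyethyl on a double-bonded ring carbon. The change is therefore one at a double-bonded ring carbon of the core shared by all members, and neither measured step covers it directly. The step to compound 2 added a methoxymethyl on a chain carbon, the step to compound 3 exchanged methoxy for benzyl two bonds along the chain; both enlarged a chain and both lowered the number, the second strongly. The change to compound 4 instead removes the 2-methoxyethyl chain altogether and puts a three-membered ring of three heavy atoms in its place, so a downward step of the kind seen in the measured pairs is not expected, and a step of about a number 0.18 log units higher from compound 1 to compound 4 (within the scatter) is expected.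

On that basis compound 4 is expected to give 5.3 in this assay, in a range from 4.5 to 6.1.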

Compound 4, logarithm of the reciprocal of the active concentration, log(1/C): 5.69
For compound 4 the middle estimate is 0.39 log units below the measured one, and the stated range covers the measured number.
By their numbers in this assay, from the lowest: compound 3; then compound 2; then compound 1; then compound 4.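

In this assay, within the data shown here, the replacement at this double-bonded ring carbon gives the first upward step, a number 0.57 log units higher from compound 1 to compound 4 (beyond the scatter), whereas both earlier steps, each a change on a saturated chain carbon, ran downward. The 2-methoxyethyl chain is therefore not required for activity at this position: with the chain gone and aziridin-1-yl in its place, compound 4 gives 5.69 in this assay, so a ring-bearing group with no chain is tolerated here and the number does not fall. No supporting measurement is available to explain this rise.

From the compounds shown here alone, it remains open whether the higher number belongs specifically to aziridin-1-yl or would also appear with other small groups on this ring carbon, such as an ethyl, a dimethylamino or a morpholin-4-yl group. Also unsettled is whether the same gain would hold if the methyl group, three ring bonds from this position, gave way to a chlorine atom or a hydroxymethyl group while the aziridin-1-yl group stayed in place.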